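This account rests on a few compounds, and the source may have more. Where it says the series, first, only, none or still open, it means among the compounds named here.

Compound 1 `CC(C)Nc1cc(Oc2ccc(NC(=O)Nc3cccc(C(F)(F)F)c3)cc2)ncn1` is a urea bearing a trifluoromethyl group, and in an assay on isolated protein for inhibition of serine/threonine-protein kinase TNNI3K (Homo sapiens) (a lower number here means a stronger inhibitor, a higher number a weaker inhibitor), compound 1 gives 40 nM. Compound 2 `CC(C)(O)CNc1cc(Oc2ccc(NC(=O)Nc3cccc(C(F)(F)F)c3)cc2)ncn1` carries a 2-hydroxy-2-methylpropyl in place of isopropyl on a nitrogen on an aromatic ring, and in this assay compound 2 gives 40 nM; the step of no change at the digits printed from compound 1 to compound 2 (within the scatter) shows the two sit level, so compound 2 stands level with compound 1 on the numbers shown. Compound 3 `CN(C)c1cc(Oc2ccc(NC(=O)Nc3cccc(C(F)(F)F)c3)cc2)ncn1` changes the same nitrogen again: dimethylamino in place of (2-hydroxy-2-methylpropyl)amino on an aromatic carbon. Among the measured compounds shown here, the only step that bears on it is no change at the digits printed from compound 1 to compound 2 (within the scatter), a swap at this nitrogen that moved nothing beyond the scatter. From that single step, a further change at this place is expected to give at most a small shift, so the step of a 1.4-fold higher number from compound 2 to compound 3 (0.14 log units; within the scatter) is estimated to stay within the scatter. In this assay compound 3 is therefore expected to give about 55 nM, with a range from 20 nM to 160 nM.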

Compound 3, half-maximal inhibitory concentration: 2500 nM
The estimate for compound 3 lay 45-fold (1.66 log units) below the measured number; the measured number lies above the stated range.
By their numbers in this assay, from the lowest: compounds 1 and 2 (each within the scatter of the next); then compound 3.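

The swap from isopropylamino to (2-hydroxy-2-methylpropyl)amino made this nitrogen look tolerant, but that holds only for some groups: in this assay, dimethylamino gives a 63-fold higher number from compound 2 to compound 3 (1.80 log units; beyond the scatter) and a 63-fold higher number from compound 1 to compound 3 (1.80 log units; beyond the scatter), so the position does respond strongly to what is attached. The two groups that keep the lower numbers both leave a hydrogen on this nitrogen, whereas dimethylamino has 0 hydrogen-bond donors, a structural difference that travels with the loss. No measurement here explains the loss.

The compounds shown cannot separate the missing nitrogen hydrogen from the shape of the group, and methylamino, with a single methyl on this nitrogen, would sit between those readings. As far as these compounds go, whether a ring amine such as pyrrolidine behaves like dimethylamino also remains open.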